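A few compounds are considered here, and "the series" means these few. Any claim that something is new, unique, unknown or untested is made for them only; others in the source may bear on it.

Three analogues share one core and differ only in the aryl group on the aromatic carbon. In an assay on cells (Oocyte) for negative allosteric modulation of glutamate receptor ionotropic, NMDA 2D (Rattus norvegicus), read by two-electrode voltage clamp (a higher number here means a weaker inhibitor, a lower number a stronger inhibitor), compound 1 `O=C(O)CCC(=O)N1N=C(c2c(-c3ccc(C(F)(F)F)cc3)c3ccccc3[nH]c2=O)CC1c1ccc(Cl)cc1` gives 2800 nM, compound 2 `COc1cccc(-c2c(C3=NN(C(=O)CCC(=O)O)C(c4ccc(Cl)cc4)C3)c(=O)[nH]c3ccccc23)c1` gives 4500 nM, and compound 3 `O=C(O)CCC(=O)N1N=C(c2c(-c3cccc(C(F)(F)F)c3)c3ccccc3[nH]c2=O)CC1c1ccc(Cl)cc1` gives 2600 nM. On the numbers as they stand compound 3 sits at the low end, but its gaps to the others lie within the scatter: a 1.1-fold lower number from compound 1 to compound 3 (0.03 log units; within the scatter) and a 1.7-fold lower number from compound 2 to compound 3 (0.24 log units; within the scatter). Compound 4 `O=C(O)CCC(=O)N1N=C(c2c(-c3ccc(F)c(Cl)c3)c3ccccc3[nH]c2=O)CC1c1ccc(Cl)cc1` carries 3-chloro-4-fluorophenyl in place of 3-(trifluoromethyl)phenyl on an aromatic carbon. Every aryl swap measured so far, including a 1.6-fold higher number from compound 1 to compound 2 (0.21 log units; within the scatter), stayed within the scatter. In this assay a step of a 1.1-fold higher number from compound 3 to compound 4 (0.03 log units; within the scatter) is therefore expected, with no shift beyond the scatter. Compound 4 is expected at 2800 nM, in a range from 1300 nM to 6000 nM.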

Compound 4, half-maximal inhibitory concentration: 1000 nM
Estimate against measurement, compound 4: 2.8-fold (0.45 log units) above, outside the stated range (below it).
By their numbers in this assay, from the lowest: compound 4; then compounds 3, 1 and 2 (each within the scatter of the next).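

In this assay, this aryl position gives its first shifts beyond the scatter with 3-chloro-4-fluorophenyl (a 2.6-fold lower number from compound 3 to compound 4 (0.41 log units; beyond the scatter); a 2.8-fold lower number from compound 1 to compound 4 (0.45 log units; beyond the scatter); a 4.5-fold lower number from compound 2 to compound 4 (0.65 log units; beyond the scatter)). The earlier swaps among the trifluoromethyl and methoxy aryl groups did not separate, whereas compound 4 now stands as the strongest inhibitor of the four. Nothing available explains this shift.

Chlorine and fluorine enter together, so their separate contributions remain open. From the compounds shown here alone, how an amine or a carboxylic acid on this aryl ring would read also remains open.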